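The source may report more compounds than this note shows. Statements on the series, on what has been measured and on what is new or still open speak of the compounds shown alone.

Among the compounds with values here, compound 2 `Cc1ccc(S(=O)(=O)/N=C(/CCNC2=CC(=O)c3ccccc3C2=O)Nc2cccc(C(F)(F)F)c2)cc1` stands highest of the three compounds measured so far: in a functional assay on MCF7 cells (Homo sapiens) for cytotoxicity, read by MTT assay, with a stated time of 48 h (on this read-out higher numbers stand for weaker inhibition and lower numbers for stronger inhibition), compound 2 gives 89100 nM and no other number approaches it. Compound 1 `Cc1ccc(S(=O)(=O)/N=C(/CCNC2=CC(=O)c3ccccc3C2=O)Nc2ccc(Cl)cc2)cc1` gives 7080 nM in the same assay, and compound 3 `Cc1ccc(S(=O)(=O)/N=C(/CCNC2=CC(=O)c3ccccc3C2=O)Nc2ccc(Cl)cc2Cl)cc1` gives 17000 nM there. Compound 4 `Cc1ccc(S(=O)(=O)/N=C(/CCNC2=CC(=O)c3ccccc3C2=O)Nc2cc(F)c(F)c(F)c2)cc1` has not yet been measured; it differs from compound 2 by 3,4,5-trifluorophenyl in place of 3-(trifluoromethyl)phenyl on an amine nitrogen and so keeps the shared core while exchanging the aryl group on the amine nitrogen. Within the data shown here, two measured steps bear on this exchange, each of them moving from the 3-(trifluoromethyl)phenyl of compound 2 to another substituted phenyl on that nitrogen: a 13-fold higher number from compound 1 to compound 2 (1.10 log units; beyond the scatter) and a 5.2-fold lower number from compound 2 to compound 3 (0.72 log units; beyond the scatter) show that the 4-chlorophenyl and the 2,4-dichlorophenyl both gave lower numbers than the 3-(trifluoromethyl)phenyl, the first change large and the second modest. On that basis a lower number than compound 2 is expected for compound 4 in this assay and the expected step is a 3.6-fold lower number from compound 2 to compound 4 (0.55 log units; beyond the scatter) in size. Compound 4 is accordingly estimated at 25000 nM with a range from 6300 nM to 100000 nM around it.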

Compound 4, half-maximal inhibitory concentration: 6610 nM
Compound 4: the middle estimate sits 3.8-fold (0.58 log units) above what was measured; the measured number falls inside the stated range.
By their numbers in this assay, from the lowest: compounds 4 and 1 (each within the scatter of the next); then compound 3; then compound 2.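

In this assay, swapping one aryl group on the amine nitrogen for another with the same number of fluorine atoms moves the result sharply (a 13-fold lower number from compound 2 to compound 4 (1.13 log units; beyond the scatter)), so the fluorine count alone does not set the number at this position. The 3,4,5-trifluorophenyl and the 4-chlorophenyl cannot be told apart here (a 1.1-fold lower number from compound 1 to compound 4 (0.03 log units; within the scatter)), whereas the 2,4-dichlorophenyl remains separate from the 3,4,5-trifluorophenyl (a 2.6-fold lower number from compound 3 to compound 4 (0.41 log units; beyond the scatter)). Nothing shown accounts for these differences.

The compounds shown leave open how an unsubstituted phenyl, a methoxyphenyl or a benzyl group would read on this nitrogen. They also leave open whether the 3-(trifluoromethyl)phenyl stands alone or whether other groups carrying a trifluoromethyl would give a similar result.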